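Trifluoromethyl for fluoro on a pyridyl-pyrazolol in WI-38 growth

The compounds below may be only part of what the source reports. "The series", "measured", "known", "first", "only" and "open" are said of these compounds alone.

Measured so far:
compound 1 `Oc1cc(-c2ccccc2)nn1-c1cc(Cl)ccn1` — in an ADME assay on WI-38 cells (Homo sapiens) for inhibition, read by CellTiter-Glo, with a stated time of 4 days (a lower number here means a stronger inhibitor of growth, a higher number a weaker inhibitor of growth), compound 1 reaches only the limit > 30000 nM, which is not a number.
compound 2 `Oc1cc(-c2ccccc2)nn1-c1ccc(F)cn1` — in this assay compound 2 gives 28900 nM.

Among the measured compounds shown here, compound 2 holds the only numerical value in this set; the value of compound 1 is a limit of the assay and nothing more. Compound 2 therefore stands alone as a measured point, and it sits close to the assay limit described by the limit of > 30000 nM in this assay, at which 1 of the 2 values shown sits, so its position among the numbers is simply the one real figure available.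

Compound 3 `Oc1cc(-c2ccccc2)nn1-c1ccc(C(F)(F)F)cn1` has not yet been measured. It differs from compound 2 in one place: trifluoromethyl in place of fluoro on an aromatic carbon. No step between measured compounds connects to this change, so no shown evidence says how large its effect should be. The expectation is for a step in this assay of no more than modest size, in either direction, and most likely none beyond the usual scatter. On that basis compound 3 is estimated at 25000 nM, with a range from 9000 nM to 60000 nM. The step of a 1.2-fold lower number from compound 2 to compound 3 (0.06 log units; within the scatter) implied by this estimate is expected to stay within the scatter of repeated measurements.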

Compound 3, concentration for 50% growth inhibition: 9400 nM
The estimate for compound 3 lay 2.7-fold (0.42 log units) above the measured number; low and high end bracket the measured number.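

Trifluoromethyl in place of fluoro gives a 3.1-fold lower number from compound 2 to compound 3 (0.49 log units; beyond the scatter) in this assay, so the aromatic carbon two atoms from the ring nitrogen and para to a large group is not indifferent to what it carries. Among the compounds shown here, this is the first step that can be read in the set, and although it is modest, it lies beyond the scatter, which the earlier compounds, with no step between them, could not show. Compound 3 also gives the series a measured point that lies further from the edge of the measurable range than compound 2, which sat close to it: the limit of > 30000 nM in this assay, at which 1 of the 3 values shown sits.

A single step cannot tell which feature of trifluoromethyl accounts for the change, and the compounds shown do not say how this carbon responds to other groups, such as a nitrile, a methoxy group or an amine. They also leave open whether the same exchange would give a step of similar size if the phenyl group on the shared core were replaced, for example by a pyridine ring.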